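Swapping an amide for a benzyl group on a piperazine

The source may hold more compounds than are shown below. What is called first, only, known or untested is meant among the compounds shown, and "the series" means these compounds.

Compound 1 `COc1ccc(-c2cnc3nc(N)nc(N4CCN(C(=O)COc5ccccc5)CC4)c3n2)cc1OC` gives 4 nM in a functional assay on cells (T-cell, Homo sapiens) for inhibition; on this read-out higher numbers stand for weaker inhibition and lower numbers for stronger inhibition
Compound 2 `COc1ccc(-c2cnc3nc(N)nc(NCc4ccccc4)c3n2)cc1OC` gives 13000 nM in this assay
Compound 3 `CCOc1nc(N)nc2ncc(-c3cccc(OC)c3)nc12` gives 8300 nM in this assay

Among these three, compound 1 stands lowest in this assay; compound 3 sits far above it and compound 2 further still, both gaps lying beyond the scatter. Compound 4 `COc1ccc(-c2cnc3nc(N)nc(N4CCN(Cc5ccccc5)CC4)c3n2)cc1OC` keeps the core of compound 1 and differs from it in one place: benzyl in place of (phenoxymethyl)carbonyl on an amine nitrogen in a ring. For the measured compounds named here, no pair of measured compounds differs in exactly this way, so the size of the step cannot be read from the data. The expectation is a moderate rise in this assay, beyond the scatter, with an estimated step of a 7.5-fold higher number from compound 1 to compound 4 (0.88 log units; beyond the scatter). Compound 4 is estimated at 30 nM, within a range from 5 nM to 300 nM.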

Compound 4, half-maximal inhibitory concentration: 900 nM
Compound 4: middle estimate off by 30-fold (1.48 log units), on the low side, outside the stated range (above it).
By their numbers in this assay, from the lowest: compound 1; then compound 4; then compounds 3 and 2 (each within the scatter of the next).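

In this assay, benzyl in place of (phenoxymethyl)carbonyl on the amine nitrogen in the ring gives a 230-fold higher number from compound 1 to compound 4 (2.35 log units; beyond the scatter) and so counts as a large step, showing that this position is far from indifferent to what it carries. Both groups hold a six-membered aromatic ring of carbon only, so that ring alone does not secure the low number of compound 1. Nothing on hand explains the step.

The change removes the carbonyl and the ether oxygen together, and their shares cannot be told apart. A benzoyl or phenylacetyl group on the same nitrogen would separate them.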